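The compounds below may be only part of what the source reports. "The series", "measured", "known", "first", "only" and "open" are said of these compounds alone.

Compound 1 `CCCCCC(=O)N[C@@H]1CCN(c2cc(C)nn3c(-c4ccc(OC)c(OC)c4)c(C)nc23)C1`: > 95% (a limit)
Compound 2 `COc1ccc(-c2c(C)nc3c(N4CC[C@@H](NS(C)(=O)=O)C4)cc(C)nn23)cc1OC`: > 95% (a limit)

Both entries come from an ADME assay on microsomes from liver (Homo sapiens) for metabolic stability, read by LC-MS, with NADPH named in the record, with a stated time of 60 min, tested at 1 uM, in the absence of a further agent (on this read-out lower numbers stand for a less stable compound and higher numbers for a more stable compound), and neither is an exact number. Compound 2 stands at > 95%, which is a limit of the assay. Compound 3 `COc1ccc(-c2c(C)nc3c(N4CC[C@@H](NS(=O)(=O)C(C)C)C4)cc(C)nn23)cc1OC` differs from compound 2 in one place, with isopropyl in place of methyl on a sulfonyl sulfur. For the measured compounds named here, the only measured step is a step that the two limits leave unreadable from compound 1 to compound 2, where methylsulfonyl takes the place of pentylcarbonyl on an amine nitrogen, so it offers no size to carry over. It is still informative that compound 1, with its pentylcarbonyl, reports > 95%, again a limit. No change beyond the usual scatter is therefore expected, although a small loss would not surprise, and the expected step is a number at least 3 percentage points lower from compound 2 to compound 3 (that floor lies within the scatter). For compound 3 the estimate is 92%, with an expected range of 75% to 100%.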

Compound 3, percent of the compound remaining: > 95%
Compound 3: a limit, no number (the forecaster's own chance of this, stated with the estimate: 50%); at least 3 percentage points between middle value and limit.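

The steps among compound 1, compound 2 and compound 3 cannot be read, as all three stand at one limit: the limit of > 95% in this assay, at which 3 of the 3 values shown sit.

Going by these compounds, what stays open is how stable each compound truly is in this assay, and whether isopropyl in place of methyl on a sulfonyl sulfur changes that at all.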